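Compound 4: Fluoro in Place of Ethoxy

The source may hold more compounds than are shown below. What is called first, only, known or untested is meant among the compounds shown, and "the series" means these compounds.

Measured so far in a functional assay on A549 cells (Homo sapiens) for antiproliferative activity, read by MTT assay, with a stated time of 72 h (on this read-out lower numbers stand for stronger inhibition and higher numbers for weaker inhibition), are these compounds:
Compound 1 `COc1cc(-n2ncnc2-c2ccc(C)cc2)cc(OC)c1OC` gives 1100 nM as a measured number.
Compound 2 `COc1cc(-n2ncnc2-c2ccc(Cl)c(Cl)c2)cc(OC)c1OC` gives > 10000 nM as a limit of the assay.
Compound 3 `CCOc1cccc(-c2ncnn2-c2cc(OC)c(OC)c(OC)c2)c1` gives > 10000 nM as a limit of the assay.

Compound 3 has no number, only a limit (the limit of > 10000 nM in this assay, at which 2 of the 3 values shown sit). Compound 4 `COc1cc(-n2ncnc2-c2cccc(F)c2)cc(OC)c1OC` has not yet been measured. It differs from compound 3 in one place, with fluoro in place of ethoxy on an aromatic carbon, meta to a large group (fluoro in place of ethoxy on an aromatic carbon). Among the measured compounds shown here, the only measured step that bears on this change is an at least 9.0-fold higher number from compound 1 to compound 2 (0.95 log units; beyond the scatter) and it shows that a swap of substituents on this ring can move a compound a long way in this assay. For the measured compounds named here, no measured step shows what fluoro itself does, so the size of the move remains uncertain, and another limit is possible. The estimate means an at least 2.0-fold lower number from compound 3 to compound 4 (0.30 log units; that floor lies within the scatter) as the expected step, in the direction of stronger inhibition. The expected value for compound 4 is 5000 nM within an estimated range from 700 nM to 20000 nM at its two ends.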

Compound 4, half-maximal inhibitory concentration: > 10000 nM
Compound 4 gave a limit, no number (the forecaster's own chance of this, stated with the estimate: 40%); at least 2.0-fold (0.30 log units) between middle value and limit.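

In this assay, 3-fluorophenyl in place of 4-methylphenyl gives an at least 9.0-fold higher number from compound 1 to compound 4 (0.95 log units; beyond the scatter), so a single fluoro on this ring does not keep the activity that compound 1 shows. Fluoro in place of ethoxy does not bring the compound off the limit either, and among the compounds shown only compound 1 gives a number: the limit of > 10000 nM in this assay, at which 3 of the 4 values shown sit. The steps that link compound 4 to compound 2 and to compound 3 cannot be read, since both ends of each are limits.

From the compounds shown here alone, how compound 2, compound 3 and compound 4 rank among themselves therefore stays open. Also open, going by these compounds, is what a hydroxy group, an amine or a longer chain would do on this aromatic carbon of the shared core.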